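The compounds below may be only part of what the source reports. "The series", "measured", "known", "first", "only" and "open" are said of these compounds alone.

Compound 1 `C=CCOc1ccc(F)cc1C(=O)c1cccnc1` and compound 2 `O=C(c1cccnc1)c1cc(Cl)ccc1O` share a core and were both run in a functional assay on MCF7 cells (Homo sapiens) for cytotoxicity, read by sulforhodamine B assay, with a stated time of 48 h; a lower number here means a stronger inhibitor, a higher number a weaker inhibitor. In this assay compound 2 gives 29000 nM. For compound 1 this assay reports only a limit, > 100000 nM, and so no number is known for it. Compound 1 thus stands at the limit of > 100000 nM in this assay, at which 1 of the 2 values shown sits, and the two results cannot be ordered beyond saying that compound 2 returned a number and compound 1 did not. Compound 3 `C=CCOc1ccccc1C(=O)c1cccnc1` has not yet been measured in this assay. It differs from compound 1 by hydrogen in place of fluoro on an aromatic carbon. Among the measured compounds shown here, no measured pair here separates hydrogen from fluoro, so the step is expected to be small, likely none beyond the scatter, and compound 3 will most probably again be reported as a limit rather than a number. The step expected is a number no higher from compound 1 to compound 3 (the limit leaves the size open). Compound 3 is estimated at 100000 nM, within a range from 30000 nM to 300000 nM.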

Compound 3, half-maximal inhibitory concentration: > 100000 nM
Compound 3: no number, only a limit; the forecaster's own chance of this, stated with the estimate: 65%; the middle value lies on the limit itself.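

Compound 1 and compound 3 are both reported only as limits in this assay, so no step can be read between them: the limit of > 100000 nM in this assay, at which 2 of the 3 values shown sit. The compounds shown leave open what hydrogen in place of fluoro on an aromatic carbon does to the read-out in this assay.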